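Ring for Chain: Expected Growth Inhibition of Compound 4

The source may report more compounds than this note shows. Statements on the series, on what has been measured and on what is new or still open speak of the compounds shown alone.

Measured compounds:
compound 1, `CCCCCCC[C@H]1C[C@H](Br)CCN1S(=O)(=O)c1ccc(C)cc1`: > 100000 nM
compound 2, `Cc1ccc(S(=O)(=O)N2CC[C@@H](Br)C[C@@H]2C2CCCCC2)cc1`: 14000 nM
compound 3, `CCCCCCCC1C=C(Br)CCN1S(=O)(=O)c1ccc(C)cc1`: 40000 nM

All three were tested in a functional assay on WiDr cells (Homo sapiens) for antiproliferative activity, read by sulforhodamine B assay, with a stated time of 48 h; a higher number here means a weaker inhibitor of growth, a lower number a stronger inhibitor of growth. The value of compound 1 is a limit of the assay, not a number (the limit of > 100000 nM in this assay, at which 1 of the 3 values shown sits). Compound 2 differs from compound 1 by one change, (cyclohexyl in place of heptyl on a saturated ring carbon), and that change made a step of an at least 7.1-fold lower number from compound 1 to compound 2 (0.85 log units; beyond the scatter). Compound 3 stands on a different core; how the core of compound 3 differs from that of compound 1 is not broken down here. Of the two numbers in hand, compound 3 gives the higher one, and its nearest neighbour is compound 2.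

Compound 4, `Cc1ccc(S(=O)(=O)N2CCC(Br)=CC2C2CCCCC2)cc1`, has not yet been measured in this assay. It differs from compound 3 by cyclohexyl in place of heptyl on a saturated ring carbon, the same change as between compound 1 and compound 2, at the same place on the ring. Resting on the size of an at least 7.1-fold lower number from compound 1 to compound 2 (0.85 log units; beyond the scatter), the expected step is a 5.7-fold lower number from compound 3 to compound 4 (0.76 log units; beyond the scatter). Compound 4 is therefore estimated at 7000 nM, most likely between 2000 nM and 25000 nM.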

Compound 4, concentration for 50% growth inhibition: 18000 nM
Compound 4: middle estimate off by 2.6-fold (0.41 log units), on the low side, and the stated range covers the measured number.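

In this assay, cyclohexyl in place of heptyl gave a 2.2-fold lower number from compound 3 to compound 4 (0.35 log units; beyond the scatter), so the direction of the change carries over to the second core, but its size does not stay the same: the same change on two cores in this assay, an at least 7.1-fold lower number (0.85 log units; beyond the scatter) from compound 1 to compound 2 and a 2.2-fold lower number (0.35 log units; beyond the scatter) from compound 3 to compound 4, at least 3.2-fold (0.50 log units) apart, beyond the scatter of two such steps The value of compound 1 is a limit of the assay and not a number: the limit of > 100000 nM in this assay, at which 1 of the 4 values shown sits. The earlier step therefore has no fixed size, and two cores cannot show how large the change would be on a third core, nor why the two steps differ.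

Only heptyl and cyclohexyl are shown at this place, so it remains open how a shorter chain such as butyl, a branched group such as isopropyl, or an aromatic phenyl ring would compare. As far as these compounds go, it is also open whether a group carrying an amine or a carboxylic acid at this place would keep any growth inhibition.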